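The source may hold more compounds than are shown below. What is called first, only, known or untested is meant among the compounds shown, and "the series" means these compounds.

Compound 1 `O=[N+]([O-])c1ccc(N/N=C(/c2ccc(O)cc2)c2cccc3ccccc23)c([N+](=O)[O-])c1`: 7020 nM
Compound 2 `Cc1ccc(/C=C2\CN(C(=S)NC(=O)c3ccccc3)C/C(=C\c3ccc(C)cc3)C2=O)cc1`: < 10000 nM

Both compounds were tested in a functional assay on MDA-MB-231 cells (Homo sapiens) for antiproliferative activity, read by MTT assay, with a stated time of 48 h; on this read-out higher numbers stand for weaker inhibition and lower numbers for stronger inhibition. Compound 2 has no exact number there and stands only at a limit of the assay: the limit of < 10000 nM in this assay, at which 1 of the 2 values shown sits. Compound 3 `CCCCNC(=S)N1C/C(=C\c2ccc(C)cc2)C(=O)/C(=C/c2ccc(C)cc2)C1` carries butyl in place of benzoyl on an amide-type nitrogen. Among the compounds with values here, no measured step bears on this change, so no shift beyond the scatter is expected in this assay, in either direction. The estimated step runs a step that the limit leaves unreadable from compound 2 to compound 3. For compound 3 the expected value is 6000 nM, with an estimated range of 2000 nM to 15000 nM.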

Compound 3, half-maximal inhibitory concentration: < 10000 nM
Compound 3: a limit, no number; the forecaster's own chance of this, stated with the estimate: 30%; the middle value lies beyond the limit too.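

No step can be read between compound 2 and compound 3 in this assay, because both stand only at a limit, not at a number: the limit of < 10000 nM in this assay, at which 2 of the 3 values shown sit. As far as these compounds go, whether butyl in place of benzoyl on an amide-type nitrogen shifts the inhibition in this assay stays open.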